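The source may report more compounds than this note shows. Statements on the series, on what has been measured and on what is new or still open speak of the compounds shown alone.

- Compound 1 `O=S(=O)(Nc1cccc(CO)c1)c1ccc(-c2ccccc2)cc1` gives 1100 nM
- Compound 2 `O=S(=O)(Nc1cccc(CO)c1)c1ccc(-c2ccc(Br)cc2)cc1` gives 3000 nM

Going by the values given here, compound 2 at 3000 nM stands highest of the two numbers so far in a functional assay on cells (Osteoclast, Mus musculus) for inhibition, with a stated time of 10 days (on this read-out lower numbers stand for stronger inhibition and higher numbers for weaker inhibition), and compound 1 lies below it. Compound 3 `O=S(=O)(Nc1cccc(CO)c1)c1ccc(-c2ccc(F)cc2F)cc1` has not yet been measured. It differs from compound 2 by 2,4-difluorophenyl in place of 4-bromophenyl on an aromatic carbon with 2,4-difluorophenyl in place of 4-bromophenyl on an aromatic carbon. Among the compounds with values here, one measured step bears on this change, and it is modest: a 2.7-fold higher number from compound 1 to compound 2 (0.44 log units; beyond the scatter) for bromo in place of hydrogen on an aromatic carbon. Within the data shown here, compound 3 has no bromo, so a modest move to a lower number in this assay is expected, although no measured step shows what fluoro does here. The expected change is a 2.1-fold lower number from compound 2 to compound 3 (0.33 log units; beyond the scatter) and it remains uncertain. Compound 3 is estimated at 1400 nM with an expected range of 500 nM to 4000 nM as its limits.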

Compound 3, half-maximal inhibitory concentration: 200 nM
Beside the measured number, compound 3's estimate is 7.0-fold (0.85 log units) above it, and the stated range ends above it.
By their numbers in this assay, from the lowest: compound 3; then compound 1; then compound 2.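

In this assay, going by these compounds alone, the outer aromatic ring proves able to move the read-out in both directions: the only earlier step, with bromo, went to a higher number, whereas this change gives a 15-fold lower number from compound 2 to compound 3 (1.18 log units; beyond the scatter) and also a 5.5-fold lower number from compound 1 to compound 3 (0.74 log units; beyond the scatter) when set against the unsubstituted phenyl. Substitution on this ring is therefore not simply unfavourable, and what enters matters: 2,4-difluorophenyl places compound 3 lowest of the three, with both of its steps beyond the scatter. No supporting measurement bears on why the two halogen patterns part so widely.

The compounds shown do not separate the contributions of the two fluorines within the 2,4-difluorophenyl group. They also leave open how this ring would respond to a chloro or methoxy group, an amine or a carboxylic acid.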